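The source may hold more compounds than are shown below. What is called first, only, known or untested is meant among the compounds shown, and "the series" means these compounds.

Measured in an assay on CHO cells for agonist activity at Glucose-dependent insulinotropic receptor (Homo sapiens), read by a luciferase reporter and cAMP accumulation, with a stated time of 2 h (on this read-out lower numbers stand for an effect already at smaller amounts and higher numbers for an effect only at larger amounts of compound), so far:
- compound 1 `CC(C)c1noc(N2CCC(Oc3cc(N4CCc5cc(N6CCCNS6(=O)=O)ccc54)ncn3)CC2)n1` gives 24 nM
- compound 2 `CC(C)SC(=O)N1CCC(Oc2cc(N3CCc4cc(S(C)(=O)=O)ccc43)ncn2)CC1` gives 3.2 nM
- compound 3 `CC(C)SC(=O)N1CCC(Oc2cc(N3CCc4cc([S+]([O-])CCO)ccc43)ncn2)CC1` gives 14 nM; 57 nM; 9.7 nM (3 entries)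

In this assay compound 1 stands at the highest of the two single numbers; the nearest is compound 2, whose number is lower by a gap beyond the scatter, while compound 3 has several entries and no single number. The repeats of compound 3 the several entries of compound 3 in this assay, 14 nM; 57 nM; 9.7 nM (3 entries) show how far repeated runs of this assay can spread.

Compound 4 `CC(C)c1noc(N2CCC(Oc3cc(N4CCc5cc(N6CCOCC6=O)ccc54)ncn3)CC2)n1` is not yet measured. It differs from compound 1 in one place a group of 7 heavy atoms (4 carbon, 1 nitrogen, 2 oxygen; one six-membered non-aromatic ring with 2 hetero atoms) in place of a group of 8 heavy atoms (3 carbon, 2 nitrogen, 2 oxygen, 1 sulfur; one six-membered non-aromatic ring with 3 hetero atoms), on an aromatic carbon, meta to a fused ring and para to a fused ring. Within the data shown here, no pair of measured compounds covers this exchange, so no direction beyond the scatter is expected; the step from compound 1 to compound 4 is estimated as a 1.3-fold higher number from compound 1 to compound 4 (0.10 log units; within the scatter), small and toward a slightly higher number at most. Compound 4 is therefore expected near 30 nM, with a range from 8 nM to 120 nM.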

Compound 4, half-maximal effective concentration: 15 nM
Beside the measured number, compound 4's estimate is 2.0-fold (0.30 log units) above it, within the range that was stated.
By their numbers in this assay, from the lowest: compound 2; then compounds 4 and 1 (each within the scatter of the next).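

In this assay, among these compounds, the exchange on this aromatic carbon, meta to a fused ring and para to a fused ring, gives a 1.6-fold lower number from compound 1 to compound 4 (0.20 log units; within the scatter), the first reading of any change at this place. The hydrogen-bond donor and the sulfur counted in the leaving group are absent from the 3-oxomorpholin-4-yl group, yet the number stays level, so neither is needed at this place for a value of this size in this frame. A step of this size also sits well inside the spread of repeated runs: the several entries of compound 3 in this assay, 14 nM; 57 nM; 9.7 nM (3 entries)

As far as these compounds go, whether an open-chain amine or a carboxylic acid on this aromatic carbon would stay in the same range remains open. Also open, from the compounds shown here alone, is whether the 3-oxomorpholin-4-yl group would read the same way on the frame of compound 2.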